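The source may report more compounds than this note shows. Statements on the series, on what has been measured and on what is new or still open speak of the compounds shown alone.

Measured in a toxicity assay on MDCK cells (Canis lupus familiaris) for cytotoxicity, read by crystal violet staining, with a stated time of 48 h; a lower number here means that less compound is tolerated, a higher number that more compound is tolerated:
Compound 1, `CC(C)c1ccc2[nH]c(=O)c(CN(Cc3ccc(F)cc3)Cc3ccc(C(C)(C)C)cc3)cc2c1`, gives 7900 nM.
Compound 2, `Cc1ccc2[nH]c(=O)c(CN(Cc3cccc(F)c3)Cc3ccc4ccccc4c3)cc2c1`, reports only a limit, > 5000 nM.
Compound 3, `COc1ccc(CN(Cc2ccc(C(C)(C)C)cc2)Cc2cc3cc(C)ccc3[nH]c2=O)cc1`, reports only a limit, > 10000 nM.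

Compound 3 thus stands at the limit of > 10000 nM in this assay, at which 1 of the 3 values shown sits, so its result is a bound, not a number. Compound 2 likewise stands at the limit of > 5000 nM in this assay, at which 1 of the 3 values shown sits. No step between measured compounds is shown, so only the three values themselves speak, and all three sit high in this assay. Compound 4, `Cc1ccc2[nH]c(=O)c(CN(Cc3ccc(SC(F)(F)F)cc3)Cc3ccc(C(C)(C)C)cc3)cc2c1`, differs from compound 3 by (trifluoromethyl)sulfanyl in place of methoxy on an aromatic carbon. Among the measured compounds shown here, with no measured step on such a change, compound 4 is expected to stay close to compound 3, with a step of an at least 1.2-fold lower number from compound 3 to compound 4 (0.09 log units; that floor lies within the scatter) expected to be small or none beyond the scatter. Compound 4 is therefore estimated at 8000 nM, within 3000 nM to 20000 nM.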

Compound 4, half-maximal cytotoxic concentration: > 5000 nM
Compound 4: no number, only a limit (the forecaster's own chance of this, stated with the estimate: 40%); the middle value is on the limit's open side.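

Among the compounds shown here, compound 3 and compound 4 both report only limits in this assay, so no step between them can be read. The compounds shown leave open whether (trifluoromethyl)sulfanyl in place of methoxy changes the half-maximal cytotoxic concentration at all.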